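The source may hold more compounds than are shown below. What is called first, only, known or untested is meant among the compounds shown, and "the series" means these compounds.

For the measured compounds named here, compound 1 `CN1CCN(c2ccc(Nc3ncc4nc(Nc5ccc(F)cc5)n(-c5cccc(NC(=O)CO)c5)c4n3)cc2)CC1` is the one member of this small set that comes with a number: in a functional assay on A549 cells (Homo sapiens) for antiproliferative activity, read by MTT assay, with a stated time of 72 h (on this read-out higher numbers stand for weaker inhibition and lower numbers for stronger inhibition), compound 1 gives 1510 nM. Compound 2 `CN1CCN(c2ccc(Nc3ncc4nc(Nc5ccccc5)n([C@H]5CCN(S(C)(=O)=O)C5)c4n3)cc2)CC1` and compound 3 `CC(=O)N1CC[C@H](n2c(Nc3ccccc3)nc3cnc(Nc4ccc(N5CCN(C)CC5)cc4)nc32)C1` share the same core, but for compound 2 the entry in this assay reads "not determined" (no result reported), and for compound 3 the entry reads "not determined" (no result reported), so compound 1 stands alone as the only reference point. Compound 4 `CN1CCN(c2ccc(Nc3ncc4nc(Nc5ccc(F)cc5)n([C@H]5CCN(S(=O)(=O)C6CC6)C5)c4n3)cc2)CC1` differs from compound 1 in a single place: 1-(cyclopropylsulfonyl)pyrrolidin-3-yl in place of 3-(((hydroxymethyl)carbonyl)amino)phenyl on an aromatic nitrogen. Going by the values given here, no measured pair in this set shows what such an exchange does, so its direction cannot be read from the data. The step of a 1.7-fold lower number from compound 1 to compound 4 (0.22 log units; within the scatter) is expected to be small, probably no larger than the usual scatter between repeated runs. The estimate for compound 4 is 900 nM, with a range from 250 nM to 3500 nM.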

Compound 4, half-maximal inhibitory concentration: 150 nM
Compound 4: middle estimate off by 6.0-fold (0.78 log units), on the high side; the measured number lies below the stated range.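

In this assay, putting 1-(cyclopropylsulfonyl)pyrrolidin-3-yl in place of 3-(((hydroxymethyl)carbonyl)amino)phenyl gives a 10-fold lower number from compound 1 to compound 4 (1.00 log units; beyond the scatter), so the group on this aromatic nitrogen can shift the read-out beyond the scatter, towards stronger inhibition. The exchange alters several features at once: the six-membered aromatic ring goes, the hydrogen-bond donors go, and sulfur and a defined stereocentre arrive. No measurement here explains the shift. The compounds shown do not separate the contributions of these features. From the compounds shown here alone, what a simple amine or a carboxylic acid on the pyrrolidine ring would do also remains open.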